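The source may report more compounds than this note shows. Statements on the series, on what has been measured and on what is new or still open speak of the compounds shown alone.

Compound 1 `N#Cc1ccc(-n2c(=O)n(Cc3cccnc3)c3ccccc32)cc1C(F)(F)F` and compound 2 `N#Cc1ccc(-n2c(=O)n(Cc3ccccc3)c3cccnc32)cc1C(F)(F)F` carry the same core and differ only in where a ring nitrogen sits. In a physicochemical assay for solubility (a higher number here means a more soluble compound, a lower number a less soluble compound), compound 1 gives 2500 nM. Compound 2 yields only < 500 nM, which is a limit of the assay and not a number. Among the measured compounds shown here, compound 1 thus stands as the only true number here, with one further entry being (the limit of < 500 nM in this assay, at which 1 of the 2 values shown sits).

Compound 3 `CNC(=O)c1ccc(-n2c(=O)n(-c3ccc(C#N)c(C(F)(F)F)c3)c3ccccc32)cc1F` departs from compound 1 by 3-fluoro-4-(methylcarbamoyl)phenyl in place of (pyridin-3-yl)methyl on an aromatic nitrogen. For the measured compounds named here, no measured step between two compounds differing in one place is available, so the size of this change cannot be read off directly. Still, compound 3 is expected to be less soluble than compound 1, and the step of a 2.8-fold lower number from compound 1 to compound 3 (0.44 log units; beyond the scatter) is estimated to lie beyond the usual scatter. For compound 3 the expected solubility in this assay is 900 nM, most likely between 300 nM and 3000 nM, with a real chance that only a limit is reported.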

Compound 3, solubility: 8810 nM
Compound 3: the middle estimate sits 9.8-fold (0.99 log units) below what was measured, outside the stated range (above it).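

At this aromatic nitrogen, putting 3-fluoro-4-(methylcarbamoyl)phenyl in place of (pyridin-3-yl)methyl gives, in this assay, a 3.5-fold higher number from compound 1 to compound 3 (0.55 log units; beyond the scatter). The entering group is the larger of the two and brings a hydrogen-bond donor that the leaving group lacks, yet the number goes up, so in this one pair the bigger group does not come with a lower reading. Nothing shown here explains the rise.

This single swap changes several features at once, so it cannot say whether the methylcarbamoyl group, the fluorine or the loss of the ring nitrogen accounts for the step. Going by these compounds, how the number would respond to an amine or a carboxylic acid on the ring at this position also remains open.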